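Bromo in Place of Fluoro: Expected Growth Inhibition of Compound 4

The source may report more compounds than this note shows. Statements on the series, on what has been measured and on what is new or still open speak of the compounds shown alone.

The measured compounds and their values:
Compound 1, `O=C(/C=C\c1ccccc1O)N1N=C(c2ccncc2)OC1c1c[nH]c2ccccc12`, gives > 30 ug/mL in an ADME assay on A549 cells (Homo sapiens) for cytotoxicity, read by MTT assay, with a stated time of 48 h (on this read-out higher numbers stand for weaker inhibition of growth and lower numbers for stronger inhibition of growth), which is a limit of the assay and not a number.
Compound 2, `O=C(/C=C\c1cccc([N+](=O)[O-])c1)N1N=C(c2ccncc2)OC1c1c[nH]c2ccccc12`, gives > 30 ug/mL in this assay, again a limit.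
Compound 3, `O=C(/C=C\c1cccc(F)c1)N1N=C(c2ccncc2)OC1c1c[nH]c2ccccc12`, gives > 30 ug/mL in this assay, also a limit.

Compound 3 therefore stands only at a limit, and the two other values shown are limits as well, as the limit of > 30 ug/mL in this assay, at which 3 of the 3 values shown sit, records. The steps among the measured compounds, a step that the two limits leave unreadable from compound 1 to compound 2, a step that the two limits leave unreadable from compound 1 to compound 3 and a step that the two limits leave unreadable from compound 2 to compound 3, are all left unreadable by these limits.

Compound 4, `O=C(/C=C\c1cccc(Br)c1)N1N=C(c2ccncc2)OC1c1c[nH]c2ccccc12`, differs from compound 3 by bromo in place of fluoro on an aromatic carbon. The step that bears most nearly on this change is a step that the two limits leave unreadable from compound 2 to compound 3, since it too swaps one group on an aromatic carbon of the same ring, but its size cannot be read. Among the compounds with values here, no measured step in this assay therefore gives a direction or a size, and nothing in the data suggests that compound 4 should leave the region where compounds 1, 2 and 3 sit.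

Compound 4 is accordingly expected to give about 45 ug/mL in this assay, within 20 ug/mL to 120 ug/mL. The step this estimate means, a step that the limit leaves unreadable from compound 3 to compound 4, is expected to be no step beyond the scatter, most likely ending again at a limit.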

Compound 4, concentration for 50% growth inhibition: > 30 ug/mL
Compound 4 was reported as a limit; the forecaster's own chance of this, stated with the estimate: 80%; the middle value does not contradict the limit.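

Compound 4 ends at a limit of the assay, as do compound 1, compound 2 and compound 3, so no step among these compounds can be read in this assay: the limit of > 30 ug/mL in this assay, at which 4 of the 4 values shown sit.

The compounds shown leave open how strongly any of them inhibits growth, and whether exchanging the groups on the aromatic ring changes it at all.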